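A few compounds are considered here, and "the series" means these few. Any claim that something is new, unique, unknown or untested is made for them only; others in the source may bear on it.

Measured in a functional assay on PC-3 cells (Homo sapiens) for antiproliferative activity, read by MTT assay, with a stated time of 24 h; on this read-out lower numbers stand for stronger inhibition and higher numbers for weaker inhibition:
compound 1 `CCN(CC)CCNC(=O)c1ccc(C(CC)(CC)c2ccc(OCS(=O)(=O)c3ccccc3)c(C)c2)n1CC` gives 7130 nM
compound 2 `CCn1c(C(=O)N[C@@H](CO)C(C)C)ccc1C(CC)(CC)c1ccc(OCS(=O)(=O)c2ccccc2)c(C)c1` gives 10600 nM
compound 3 `CCn1c(C(=O)N[C@@H](CO)CCO)ccc1C(CC)(CC)c1ccc(OCS(=O)(=O)c2ccccc2)c(C)c1` gives 14100 nM

Compound 3 stands within the scatter of both other compounds, with a 2.0-fold higher number from compound 1 to compound 3 (0.30 log units; within the scatter) and a 1.3-fold higher number from compound 2 to compound 3 (0.12 log units; within the scatter) as its steps. Compound 4 `CCn1c(C(=O)N[C@@H](C)C(=O)O)ccc1C(CC)(CC)c1ccc(OCS(=O)(=O)c2ccccc2)c(C)c1` carries 1-carboxyethyl in place of 3-hydroxy-1-(hydroxymethyl)propyl on an amide-type nitrogen. Among the measured compounds shown here, no measured compound has this group, so the only guide is the other changes at that nitrogen, which also include a 1.5-fold higher number from compound 1 to compound 2 (0.17 log units; within the scatter) and all stay within the scatter. No step beyond the scatter is therefore expected in this assay for this change. The expected step is a 1.1-fold higher number from compound 3 to compound 4 (0.03 log units; within the scatter) and nothing larger. Compound 4 is expected at 15000 nM with an estimated range from 7000 nM to 32000 nM in this read-out.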

Compound 4, half-maximal inhibitory concentration: 16800 nM
Beside the measured number, compound 4's estimate is 1.1-fold (0.05 log units) below it; low and high end bracket the measured number.
By their numbers in this assay, from the lowest: compounds 1, 2, 3 and 4 (each within the scatter of the next, the first and the last beyond it).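

In this assay, among the compounds shown here, 1-carboxyethyl on the amide-type nitrogen gives the first step beyond the scatter at this position, and only a modest one, against 2-(diethylamino)ethyl (a 2.4-fold higher number from compound 1 to compound 4 (0.37 log units; beyond the scatter)). Against 3-hydroxy-1-(hydroxymethyl)propyl (a 1.2-fold higher number from compound 3 to compound 4 (0.08 log units; within the scatter)) and 1-(hydroxymethyl)-2-methylpropyl (a 1.6-fold higher number from compound 2 to compound 4 (0.20 log units; within the scatter)), it stays within the scatter. No measurement available here accounts for these steps.

Open, as far as these compounds go, is whether a primary amine or a longer chain ending in a carboxylic acid on this nitrogen would give a larger step.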